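Phenyl in Place of Ethyl on Compound 2

A few compounds are considered here, and "the series" means these few. Any claim that something is new, unique, unknown or untested is made for them only; others in the source may bear on it.

Compound 1, `Cc1cc(NC(=O)c2ccc3ccccc3c2)ccc1-c1cnc(OCC(C)(C)C(=O)O)cn1`, in an assay on 3T3-L1 cells for inhibition of diacylglycerol O-acyltransferase 1 (Mus musculus) (on this read-out lower numbers stand for stronger inhibition and higher numbers for weaker inhibition), gives 2160 nM.
Compound 2, `CCC(Sc1nnc(-c2ccc(NC(=O)c3ccc(Cl)c(Cl)c3)cc2)n1C)C(=O)O`, returns only a limit of this assay, > 20000 nM.
Compound 3, `CC(Sc1nnc(-c2ccc(NC(=O)c3ccccc3)cc2)n1C)C(=O)O`, likewise returns only a limit, > 20000 nM.

Of the three measured compounds, only compound 1 comes with an actual number. Compound 2 stands at the limit of > 20000 nM in this assay, at which 2 of the 3 values shown sit, so no number is known for it, and compound 3 shares that position. Among the compounds with values here, no two measured compounds differ in a single place, so there is no measured step to lean on.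

The unmeasured compound 4, `Cn1c(SC(C(=O)O)c2ccccc2)nnc1-c1ccc(NC(=O)c2ccc(Cl)c(Cl)c2)cc1`, differs from compound 2 in one place: phenyl in place of ethyl on a saturated chain carbon bound to a carbonyl carbon and a sulfur. The change sits on a saturated chain carbon bound to a carbonyl carbon and a sulfur, while the rest of compound 2 is kept.

Within the data shown here, with no measured step of this kind, the size of the change cannot be read from the data. In this assay the expected step is a number no higher from compound 2 to compound 4 (the limit leaves the size open), that is, nothing beyond the scatter. Compound 2 sits at a limit, > 20000 nM. Compound 4 is therefore expected most often to return only a limit as well. As a number, compound 4 is estimated at 20000 nM, with a range from 5000 nM to 60000 nM.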

Compound 4, half-maximal inhibitory concentration: > 20000 nM
Compound 4: a limit, no number; the forecaster's own chance of this, stated with the estimate: 75%; the middle value sits exactly at the limit.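

In this assay compound 4 returns only a limit, > 20000 nM. Compound 2 also sits at a limit, so no step can be read between compound 2 and compound 4. The compounds shown leave open what actual numbers these two would give, and so whether phenyl in place of ethyl changes inhibition at all.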